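Moving the alkyl groups around an amide ring

The source may hold more compounds than are shown below. What is called first, only, known or untested is meant among the compounds shown, and "the series" means these compounds.

Three compounds share one core and differ only in the group attached to the amide carbonyl. Compound 1 `O=C(Nc1cccc(-c2oc3cc(-c4ccc(F)cc4)ccc3c(=O)c2O)c1)c1ccc(C(F)(F)F)cc1` carries a trifluoromethyl group on that ring, compound 2 `O=C(Nc1cccc(-c2oc3cc(-c4ccc(F)cc4)ccc3c(=O)c2O)c1)c1ccc(Br)cc1` a bromo group, and compound 3 `CCc1ccc(C(=O)Nc2cccc(-c3oc4cc(-c5ccc(F)cc5)ccc4c(=O)c3O)c2)cc1` an ethyl group. In a functional assay on MDA-MB-231 cells (Homo sapiens) for antiproliferative activity, read by CCK-8 assay, with a stated time of 72 h (a lower number here means a stronger inhibitor, a higher number a weaker inhibitor), compound 1 gives 29400 nM, compound 2 gives 24900 nM and compound 3 gives 9070 nM. The step of a 1.2-fold lower number from compound 1 to compound 2 (0.07 log units; within the scatter) lies within the usual scatter, whereas a 3.2-fold lower number from compound 1 to compound 3 (0.51 log units; beyond the scatter) and a 2.7-fold lower number from compound 2 to compound 3 (0.44 log units; beyond the scatter) both lie beyond it, so compound 3 is the most potent of the three.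

Compound 4 `Cc1cc(C)cc(C(=O)Nc2cccc(-c3oc4cc(-c5ccc(F)cc5)ccc4c(=O)c3O)c2)c1` keeps the same atoms as compound 3 but arranges them differently: 3,5-dimethylphenyl in place of 4-ethylphenyl on a carbonyl carbon. Going by the values given here, none of the measured steps bears directly on this change; each of them swapped one group on the ring for another at the same place, while here the ethyl group is replaced by two methyl groups at other places. With no guide of that kind, no step beyond the scatter is expected in either direction, though the range is wide. Compound 4 is therefore estimated at 12000 nM, between 4000 nM and 36000 nM, which corresponds to an expected step of a 1.3-fold higher number from compound 3 to compound 4 (0.12 log units; within the scatter).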

Compound 4, half-maximal inhibitory concentration: 11900 nM
Compound 4: the middle estimate sits 1.0-fold (0.00 log units) above what was measured, and the stated range covers the measured number.
By their numbers in this assay, from the lowest: compounds 3 and 4 (each within the scatter of the next); then compounds 2 and 1 (each within the scatter of the next).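

In this assay, rearranging the same atoms from 4-ethylphenyl to 3,5-dimethylphenyl on the carbonyl carbon gives a 1.3-fold higher number from compound 3 to compound 4 (0.12 log units; within the scatter) and so leaves the number essentially unchanged. The earlier compounds shown here only compared different groups at one place on the ring, whereas this result shows that two methyl groups at other places do as well as the ethyl group. The lower numbers also hold against the other two rings, with a 2.1-fold lower number from compound 2 to compound 4 (0.32 log units; beyond the scatter) and a 2.5-fold lower number from compound 1 to compound 4 (0.39 log units; beyond the scatter) in this assay, so among these four compounds the two alkyl-bearing rings stand apart from the bromo and trifluoromethyl rings, and none of the four goes against that split.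

Nothing available here explains why the alkyl-bearing rings give the lower numbers.

On these data alone, it remains open whether a single methyl group, a longer chain such as butyl, or an amine or a carboxylic acid on this ring would hold these numbers or move them, and whether the ethyl group would behave the same way at another place on the ring.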